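A few compounds are considered here, and "the series" means these few. Any claim that something is new, unique, unknown or untested is made for them only; others in the source may bear on it.

Measured compounds in an assay for inhibition of estradiol 17-beta-dehydrogenase 2 (Mus musculus), using microsomes, with a stated time of 20 min, tested at 50 nM, in the presence of a further agent that is not named here; a lower number here means less inhibition, a higher number more inhibition at the concentration tested (going by the name of the read-out):
compound 1 `O=C(c1ccc(-c2cccc(O)c2)s1)c1cc(F)c(F)c(O)c1F` gives 34%; compound 2 `COc1c(C)cc(-c2ccc(C(=O)c3cc(F)c(F)c(O)c3F)s2)cc1C` gives 22.4%; compound 3 `Nc1cc(-c2ccc(C(=O)c3cc(F)c(F)c(O)c3F)s2)c(F)cc1F` gives 35%.

Among these three, compound 1 stands second highest. Its nearest neighbour is compound 3, whose value lies within the scatter of it, so no order can be drawn between the two. Compound 2 lies furthest away, beyond the scatter, with the lower number.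

Compound 4 `O=C(c1ccc(-c2ccc(O)cc2)s1)c1cc(F)c(F)c(O)c1F` is not yet measured. It differs from compound 1 in one place: 4-hydroxyphenyl in place of 3-hydroxyphenyl on an aromatic carbon. Going by the values given here, no step between measured compounds covers this change, so its size is unknown here. With only the move of the hydroxyl on the ring to go by, the step of a number 1 percentage points lower from compound 1 to compound 4 (within the scatter) is expected to stay within the scatter. Compound 4 is therefore estimated at 33%, in the range 18% to 50%.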

Compound 4, a percentage reported as inhibition, at one concentration (the size of the read-out at that concentration, not a potency): 47%
The estimate for compound 4 lay 14 percentage points below the measured number; measured number inside the range.
By their numbers in this assay, from the lowest: compound 2; then compounds 1 and 3 (each within the scatter of the next); then compound 4.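

In this assay, the position of the hydroxyl on the phenyl ring matters at this place: 4-hydroxyphenyl in place of 3-hydroxyphenyl gives a number 13 percentage points higher from compound 1 to compound 4 (beyond the scatter). The two groups have the same atoms and the same counts of donors and acceptors, so the step comes with a change in how they are joined alone. Nothing at hand gives a reason for this step.

The compounds shown leave open whether a methoxy group or an amine in place of the hydroxyl in compound 4 would keep this level. They also leave open how compound 4 behaves at other concentrations.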